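Sulfonyl aryl replacements in a piperidine series: compound 4 outlook

The compounds below may be only part of what the source reports. "The series", "measured", "known", "first", "only" and "open" are said of these compounds alone.

Measured so far in a functional assay on DLD-1 cells (Homo sapiens) for antiproliferative activity, read by CellTiter-Glo, with a stated time of 72 h; on this read-out lower numbers stand for stronger inhibition and higher numbers for weaker inhibition:
- compound 1 `CC1CCN(C2CCN(S(=O)(=O)c3cccc(Br)c3)CC2)CC1`: 3.2 nM
- compound 2 `CCc1ccc(S(=O)(=O)N2CCC(N3CCC(C)CC3)CC2)cc1`: > 5000 nM
- compound 3 `COc1cccc(S(=O)(=O)N2CCC(N3CCC(C)CC3)CC2)c1`: > 5000 nM

Compound 2 stands at the weak end of the numbers shown. For compound 2 the value > 5000 nM is a limit of the assay, not a number. For compound 3 the value > 5000 nM is likewise a limit. The step of an at least 1500-fold higher number from compound 1 to compound 2 (3.19 log units; beyond the scatter) and the step of an at least 1500-fold higher number from compound 1 to compound 3 (3.19 log units; beyond the scatter) both show that replacing the 3-bromophenyl of compound 1 loses a great deal; the step that the two limits leave unreadable from compound 2 to compound 3 cannot be read (the limit of > 5000 nM in this assay, at which 2 of the 3 values shown sit).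

Compound 4 `CC1CCN(C2CCN(S(=O)(=O)c3ccc(-c4ccc(Cl)cc4)cc3)CC2)CC1` differs from compound 2 by 4-chlorophenyl in place of ethyl on an aromatic carbon. Going by the values given here, no measured step covers a 4-chlorophenyl entering the aryl ring, so the size of the step in this assay is uncertain; since compound 2 is at the limit, the number can only stay there or fall. The expectation for compound 4 is a modest improvement at best, an at least 1.6-fold lower number from compound 2 to compound 4 (0.22 log units; that floor lies within the scatter). Compound 4 is estimated at 3000 nM, between 500 nM and 20000 nM.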

Compound 4, half-maximal inhibitory concentration: 105 nM
The estimate for compound 4 lay 29-fold (1.46 log units) above the measured number; the whole stated range lies above it.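

In this assay, 4-chlorophenyl in place of ethyl on an aromatic carbon, para to a large group, gives an at least 47-fold lower number from compound 2 to compound 4 (1.67 log units; beyond the scatter), so this position on the sulfonyl aryl can carry a second aromatic ring and return a readable number. Going by these compounds alone, the earlier readable steps were all losses, and the step between the two compounds at the limit cannot be read; this is the first readable gain. Compound 2 gives > 5000 nM, which is a limit of the assay and not a number, so the true size of the step stays unknown: the limit of > 5000 nM in this assay, at which 2 of the 4 values shown sit.

The compounds shown leave open whether the gain belongs to the added ring or to its chlorine, which an unsubstituted phenyl at this carbon would separate. They also leave open how a pyridyl ring or an amine at this carbon would read in this assay.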